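Substituent on the ring nitrogen: from compound 3 to compound 4

This account rests on a few compounds, and the source may have more. Where it says the series, first, only, none or still open, it means among the compounds named here.

Of the compounds shown here, three have been measured in an assay on VSM-A10 cells for antagonist activity at Endothelin-1 receptor (Rattus norvegicus); on this read-out higher numbers stand for weaker inhibition and lower numbers for stronger inhibition. Compound 1 `Cc1noc(NS(=O)(=O)c2cccc3c(NC(=O)C(C)C)cccc23)c1C` carries an isopropylcarbonyl group on a nitrogen on an aromatic ring of the shared core and gives 880 nM. Compound 2 `Cc1noc(NS(=O)(=O)c2cccc3c(NCc4ccccc4)cccc23)c1C`, with benzyl on that nitrogen, gives 590 nM. The step of a 1.5-fold lower number from compound 1 to compound 2 (0.17 log units; within the scatter) lies within the scatter, so these two numbers cannot be ordered. Compound 3 `CNc1cccc2c(S(=O)(=O)Nc3onc(C)c3C)cccc12`, with methyl on the same nitrogen, gives 130 nM, the lowest of the three numbers. The steps of a 6.8-fold lower number from compound 1 to compound 3 (0.83 log units; beyond the scatter) and a 4.5-fold lower number from compound 2 to compound 3 (0.66 log units; beyond the scatter) both lie beyond the scatter, so compound 3 stands as the strongest inhibitor of the measured set.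

Compound 4 `CCOC(=O)C(C)Nc1cccc2c(S(=O)(=O)Nc3onc(C)c3C)cccc12` is not yet measured. It differs from compound 3 by 1-(ethoxycarbonyl)ethyl in place of methyl on a nitrogen on an aromatic ring. Within the data shown here, both measured steps that went beyond the scatter ran towards the smaller group on that nitrogen, as seen in a 6.8-fold lower number from compound 1 to compound 3 (0.83 log units; beyond the scatter) and a 4.5-fold lower number from compound 2 to compound 3 (0.66 log units; beyond the scatter); no measured step goes towards a larger group from methyl. The change to compound 4 runs the other way, so a modest rise in the number, beyond the scatter, is expected, with the step of a 3.1-fold higher number from compound 3 to compound 4 (0.49 log units; beyond the scatter). Compound 4 is expected to give about 400 nM in this assay, within a range from 150 nM to 1200 nM.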

Compound 4, half-maximal inhibitory concentration: 400 nM
Compound 4: the middle estimate sits on the measured number at the digits printed; measured number inside the range.
By their numbers in this assay, from the lowest: compound 3; then compounds 4, 2 and 1 (each within the scatter of the next, the first and the last beyond it).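

In this assay, among these compounds, the step of a 3.1-fold higher number from compound 3 to compound 4 (0.49 log units; beyond the scatter) is the first measured move from methyl to a larger group on the nitrogen on an aromatic ring, and it leaves compound 3 with the lowest number of the four, beyond the scatter from each of the others. With a 1.5-fold lower number from compound 2 to compound 4 (0.17 log units; within the scatter), 1-(ethoxycarbonyl)ethyl and benzyl cannot be ordered, whereas a 2.2-fold lower number from compound 1 to compound 4 (0.34 log units; beyond the scatter) separates 1-(ethoxycarbonyl)ethyl from isopropylcarbonyl, a pair of groups that differ in where the carbonyl stands relative to that nitrogen. Nothing at hand accounts for these differences.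

Still open, going by these compounds, is whether hydrogen on that nitrogen, as in the free amine, would continue the trend seen with methyl, and whether a plain ethyl group would read closer to methyl or to 1-(ethoxycarbonyl)ethyl. Also open, on these data alone, is how a carboxylic acid in place of the ethoxycarbonyl part of compound 4 would read in this assay, and what a change elsewhere on the shared core would do.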